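Trimming Ethoxy to Methoxy in Compound 3

This account rests on a few compounds, and the source may have more. Where it says the series, first, only, none or still open, it means among the compounds named here.

Of the compounds shown here, three have been measured in an ADME assay for permeability, using PAMPA, with a stated time of 18 h, tested at 25 ug/mL; on this read-out lower numbers stand for lower permeability and higher numbers for higher permeability. Compound 1 (`N#Cc1c(-c2cccc(C(F)(F)F)c2)nc(SCC(=O)Nc2nc(-c3cc(Cl)c(N)c(Cl)c3)cs2)[nH]c1=O`) gives 0.88 10^-6 cm/s and compound 2 (`COc1cccc(-c2nc(SCC(=O)Nc3nc(-c4cccc(Br)c4)cs3)[nH]c(=O)c2C#N)c1`) gives 0.94 10^-6 cm/s. Compound 3 (`CCOc1cccc(-c2nc(SCC(=O)Nc3nc(-c4cc(Cl)c(N)c(Cl)c4)cs3)[nH]c(=O)c2C#N)c1`) gives 0.07 10^-6 cm/s, the lowest of the three numbers and well apart from the other two.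

Compound 4 (`COc1cccc(-c2nc(SCC(=O)Nc3nc(-c4cc(Cl)c(N)c(Cl)c4)cs3)[nH]c(=O)c2C#N)c1`) differs from compound 3 in one place: hydrogen in place of methyl on a saturated chain carbon bound to an oxygen on an aromatic ring, which turns ethoxy into methoxy. Among the measured compounds shown here, only one measured step touches this group, a 13-fold lower number from compound 1 to compound 3 (1.10 log units; beyond the scatter). That step is large, but it exchanges trifluoromethyl for ethoxy and says nothing direct about removing a methyl. Compound 4 carries 3-methoxyphenyl, as does compound 2, but the two differ elsewhere in the structure, so compound 2 with 0.94 10^-6 cm/s gives only loose guidance. For the measured compounds named here, no measured pair isolates ethoxy from methoxy.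

The expectation therefore stays close to the starting point. In this assay the estimated step is a 1.4-fold higher number from compound 3 to compound 4 (0.15 log units; within the scatter), a small upward move that is expected to stay within the scatter. Compound 4 is estimated at 0.1 10^-6 cm/s, with an expected range of 0.03 10^-6 cm/s to 0.4 10^-6 cm/s.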

Compound 4, apparent permeability: 0.11 10^-6 cm/s
Compound 4: the middle estimate sits 1.1-fold (0.04 log units) below what was measured; the range from low to high includes it.
By their numbers in this assay, from the lowest: compounds 3 and 4 (each within the scatter of the next); then compounds 1 and 2 (each within the scatter of the next).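

In this assay, among the compounds shown here, the pair of compound 3 and compound 4 is the first to isolate this change on its own: the step is a 1.6-fold higher number from compound 3 to compound 4 (0.20 log units; within the scatter) and so stays within the scatter, which means that the loss of the methyl on the saturated chain carbon bound to an oxygen on an aromatic ring leaves the number essentially where it was. The large exchange at the aromatic carbon is also not specific to ethoxy, since methoxy in place of trifluoromethyl gives an 8.0-fold lower number from compound 1 to compound 4 (0.90 log units; beyond the scatter) and so remains beyond the scatter. With 3-methoxyphenyl held fixed, the other side of the molecule matters as well: 4-amino-3,5-dichlorophenyl in place of 3-bromophenyl gives an 8.5-fold lower number from compound 2 to compound 4 (0.93 log units; beyond the scatter) and this too lies beyond the scatter.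

Nothing in the available data accounts for any of these steps. Going by these compounds, it remains open what a longer chain such as propoxy or a free hydroxyl at this place would give, and whether ethoxy and methoxy would also stay within the scatter of each other when paired with 3-bromophenyl.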